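Tertiary alcohol in place of methoxy on the chain

The source may hold more compounds than are shown below. What is called first, only, known or untested is meant among the compounds shown, and "the series" means these compounds.

Working notes on the series. The assay is a functional assay on cells for agonist activity at Free fatty acid receptor 1 (Rattus norvegicus), read by FLIPR and calcium flux; on this read-out lower numbers stand for an effect already at smaller amounts and higher numbers for an effect only at larger amounts of compound. Compound 1 `CC#C[C@@H](Cc1nnn[nH]1)c1ccc(OCc2ccc3scc(-c4ccc(OCCCS(C)(=O)=O)cc4C)c3c2)cc1` gives 9 nM in this assay. Compound 2 `CC#C[C@@H](Cc1nnn[nH]1)c1ccc(OCc2ccc3scc(-c4ccc(OCCOC)cc4C)c3c2)cc1` gives 4 nM in this assay. Of the two measured compounds, compound 2 holds the lower number; the step of a 2.3-fold lower number from compound 1 to compound 2 (0.35 log units; beyond the scatter) lies beyond the scatter, so compound 2 stands as the more potent of the pair.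

Compound 3 `CC#C[C@@H](Cc1nnn[nH]1)c1ccc(OCc2ccc3scc(-c4ccc(OCCC(C)(C)O)cc4C)c3c2)cc1` is not yet measured. It differs from compound 2 by 1-hydroxy-1-methylethyl in place of methoxy on a saturated chain carbon, two bonds along the chain from an oxygen on an aromatic ring. Within the data shown here, only one measured step bears on this position on the chain, a 2.3-fold lower number from compound 1 to compound 2 (0.35 log units; beyond the scatter), and it was modest in size; it shows that this terminal group on the chain is tolerated with either a methoxy or a sulfonyl-bearing end, with the numbers staying close. Both measured compounds give low numbers in this assay, and the change from methoxy to 1-hydroxy-1-methylethyl is expected to move the number by no more than the scatter, in no clear direction, so the estimated step of a 1.5-fold higher number from compound 2 to compound 3 (0.18 log units; within the scatter) is small. Compound 3 is therefore estimated at 6 nM, with a range from 2.5 nM to 15 nM.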

Compound 3, half-maximal effective concentration: 4 nM
Compound 3: middle estimate off by 1.5-fold (0.18 log units), on the high side; measured number inside the range.
By their numbers in this assay, from the lowest: compounds 2 and 3 (each within the scatter of the next); then compound 1.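

In this assay, the new end brings a hydrogen-bond donor and a larger group onto the chain, where the methoxy it replaces has no donor, and the step reads no change at the digits printed from compound 2 to compound 3 (within the scatter). This position therefore accepts 1-hydroxy-1-methylethyl as readily as methoxy, which the earlier pair could not show, since neither of those compounds carries a donor on this end. The step of a 2.3-fold lower number from compound 1 to compound 3 (0.35 log units; beyond the scatter) matches in size the one already seen with methoxy, so among the three listed ends, (methylsulfonyl)methyl alone stands apart, with a modest gap and no compound going against this; no measurement on hand explains any of these differences.

Still open, on these data alone, is whether the hydroxyl of the new end contributes at all, which a methyl ether of the same tertiary alcohol or a plain isobutyl end would test. Also open, as far as these compounds go, is how far this tolerance extends in this assay to a charged end such as a carboxylic acid or an amine, or to a longer chain bearing the same tertiary alcohol.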